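Swapping a thiophene for a cyanophenyl ring

The source may report more compounds than this note shows. Statements on the series, on what has been measured and on what is new or still open speak of the compounds shown alone.

Three compounds built on one shared core have been examined in an ADME assay on HEL cells (Homo sapiens) for cytotoxicity, with a stated time of 3 days; on this read-out higher numbers stand for lower toxicity in this test and lower numbers for higher toxicity in this test. Compound 1 `Cc1cc(-c2ccc(O)cc2)cn2c(CSCCc3ccccc3)cnc12` carries a 4-hydroxyphenyl group, and in this assay compound 1 gives >= 100 ug/mL, which is a limit of the assay and not a number. Compound 2 `Cc1cc(-c2ccsc2)cn2c(CSCCc3ccccc3)cnc12` carries a thiophen-3-yl group, and in this assay compound 2 gives >= 4 ug/mL, again only a limit. Compound 3 `Cc1cc(-c2cccs2)cn2c(CSCCc3ccccc3)cnc12`, with a thiophen-2-yl group, is the only one of the three with a true number: in this assay compound 3 gives 20 ug/mL. Within the data shown here, the one readable step is an at least 5.0-fold lower number from compound 1 to compound 3 (0.69 log units; beyond the scatter); the steps a step that the two limits leave unreadable from compound 1 to compound 2 and a step that the limit leaves unreadable from compound 2 to compound 3 cannot be sized.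

Compound 4 `Cc1cc(-c2ccc(C#N)cc2)cn2c(CSCCc3ccccc3)cnc12` has not yet been measured. It differs from compound 3 by 4-cyanophenyl in place of thiophen-2-yl on an aromatic carbon, returning to a six-membered aromatic ring of carbon only, as in compound 1. Because compound 1 sits at the limit of >= 100 ug/mL in this assay, at which 1 of the 3 values shown sits, and the step of an at least 5.0-fold lower number from compound 1 to compound 3 (0.69 log units; beyond the scatter) was at least modest, a rise toward that limit is expected for compound 4, though the nitrile is not the hydroxyl and compound 2 shows a ring change need not help. Compound 4 is therefore estimated at 50 ug/mL, between 15 ug/mL and 100 ug/mL, an expected step of a 2.5-fold higher number from compound 3 to compound 4 (0.40 log units; beyond the scatter).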

Compound 4, minimum cytotoxic concentration: >= 20 ug/mL
Compound 4 ended at the assay's limit; the forecaster's own chance of this, stated with the estimate: 45%; the middle value does not contradict the limit.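

In this assay, 4-cyanophenyl in place of thiophen-2-yl on this aromatic carbon gives a number no lower from compound 3 to compound 4 (the limit leaves the size open), so a six-membered aromatic ring of carbon only, carrying a nitrile, does not pull the number down from that of the thiophen-2-yl compound. Compound 1 had left it unclear whether a phenyl ring at this place needed its hydroxyl, and compound 4 shows that a nitrile in that role also keeps the number from falling under that of compound 3. From the compounds shown here alone, the size of this step stays open, and the steps from compound 2 and from compound 1 to compound 4 cannot be read either, because compound 4 gives only a limit of the assay: the limit of >= 20 ug/mL in this assay, at which 1 of the 4 values shown sits.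

Where compound 4 truly lies relative to compound 3 and compound 1 remains unsettled, so no order of these aromatic groups can be drawn from the values shown. Going by these compounds, how a 4-aminophenyl group or a 4-carboxyphenyl group at this place would read in this assay also remains open.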